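A few compounds are considered here, and "the series" means these few. Any claim that something is new, unique, unknown or untested is made for them only; others in the source may bear on it.

Compound 1 `CN/C(=N/C#N)NCCCNc1nc(N)n[nH]1` was examined in a functional assay on Sf9 cells for antagonist activity at histamine H2 receptor (Homo sapiens), read by scintillation counting and GTPgammaS binding, with a stated time of 90 min; on this read-out higher numbers stand for higher potency (the scale is a negative logarithm) and lower numbers for lower potency. In this assay compound 1 gives only a limit of the assay, < 5. Compound 2 `N#C/N=C(\NCCCNc1nc(N)n[nH]1)NCCSc1ccccc1` differs from compound 1 as (phenylsulfanyl)methyl in place of hydrogen on a saturated chain carbon bound to an amine nitrogen. Compound 2 likewise gives only a limit, < 5. The step that the two limits leave unreadable from compound 1 to compound 2 therefore stays unreadable, because both values sit at the limit of < 5 in this assay, at which 3 of the 3 values shown sit. Compound 3 `CN/C(=N\C#N)NCCCSc1nc(N)n[nH]1` carries a different core from compound 1; how the two cores differ is not broken down here. Compound 3 gives only a limit in this assay, < 5. Compound 4 `N#C/N=C(/NCCCSc1nc(N)n[nH]1)NCCSc1ccccc1` differs from compound 3 as (phenylsulfanyl)methyl in place of hydrogen on a saturated chain carbon bound to an amine nitrogen, the same change as that made between compound 1 and compound 2. Among the measured compounds shown here, because the only measured instance of this change leaves both partners at the limit of < 5 in this assay, at which 3 of the 3 values shown sit, the step is expected to be a step that the limit leaves unreadable from compound 3 to compound 4. Compound 4 is estimated at 4.7, between 4 and 5.5.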

Compound 4, negative logarithm of the antagonist equilibrium constant: < 5
Compound 4: no number, only a limit (the forecaster's own chance of this, stated with the estimate: 70%); the middle value lies beyond the limit too.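

No step can be read from compound 3 to compound 4, since each gives only a limit of the assay: the limit of < 5 in this assay, at which 4 of the 4 values shown sit. On these data alone, whether (phenylsulfanyl)methyl in place of hydrogen changes potency in this assay at all stays open.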